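This account rests on a few compounds, and the source may have more. Where it says the series, first, only, none or still open, it means among the compounds named here.

Working notes on the series. Compound 1 `CC(=O)N1c2ccccc2CCC1C(=O)Nc1ccccc1O` in a functional assay on MDA-MB-231 cells (Homo sapiens) for cytotoxicity, read by sulforhodamine B assay, with a stated time of 72 h (on this read-out higher numbers stand for weaker inhibition of growth and lower numbers for stronger inhibition of growth), gives 89600 nM. Compound 2 `CC(=O)N1c2ccccc2CCC1C(=O)Nc1cc(C(F)(F)F)cc(C(F)(F)F)c1` in this assay reaches only a limit of the assay, > 70000 nM, so on the numbers shown compound 2 stands at the limit of > 70000 nM in this assay, at which 1 of the 2 values shown sits, and no closer. Compound 3 `CCCCCCCCC(=O)N1c2ccccc2CCC1C(=O)Nc1cc(C(F)(F)F)cc(C(F)(F)F)c1` differs from compound 2 by heptyl in place of hydrogen on a saturated chain carbon bound to a carbonyl carbon. Among the compounds with values here, no measured pair shows such a step, so the expected step of a number no higher from compound 2 to compound 3 (the limit leaves the size open) is set small, none beyond the scatter. Compound 3 is estimated at 70000 nM, with a range from 25000 nM to 200000 nM.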

Compound 3, concentration for 50% growth inhibition: 7530 nM
Beside the measured number, compound 3's estimate is 9.3-fold (0.97 log units) above it, and the stated range ends above it.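

In this assay, heptyl in place of hydrogen on a saturated chain carbon bound to a carbonyl carbon gives an at least 9.2-fold lower number from compound 2 to compound 3 (0.96 log units; beyond the scatter). Within the data shown here, this is the first sign that this position can move the read-out beyond the scatter, and the move is towards stronger inhibition of growth. Compound 2 stands at a limit of the assay, so the step has a lower bound but no fixed size: the limit of > 70000 nM in this assay, at which 1 of the 3 values shown sits.

The compounds shown leave open how the number follows chain length, from a shorter butyl to a longer undecyl. Also open, on these data alone, is whether a chain ending in an amine or a carboxylic acid would keep the step.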